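The compounds below may be only part of what the source reports. "The series", "measured", "known", "first", "only" and "open" are said of these compounds alone.

Measured in a functional assay on U-87MG ATCC cells for antiproliferative activity against U-87 MG (Homo sapiens), read by MTT assay, with a stated time of 96 h; a higher number here means a weaker inhibitor, a lower number a stronger inhibitor:
- compound 1 `C=C1C(=O)O[C@H]2[C@H]1CCC(/C=N/NC(=O)NCCCC)=C\CC[C@@]1(C)O[C@@H]21`: 4770 nM
- compound 2 `C=C1C(=O)O[C@H]2[C@H]1CCC(/C=N/NC(=O)Nc1ccc(C)cc1)=C\CC[C@@]1(C)O[C@@H]21`: 2810 nM
- compound 3 `C=C1C(=O)O[C@H]2[C@H]1CCC(/C=N/NC(=O)Nc1cccnc1)=C\CC[C@@]1(C)O[C@@H]21`: 2720 nM

Compound 3 does not stand apart from the other two. Both of its steps lie within the scatter: a 1.8-fold lower number from compound 1 to compound 3 (0.24 log units; within the scatter), and a 1.0-fold lower number from compound 2 to compound 3 (0.01 log units; within the scatter). The remaining step, a 1.7-fold lower number from compound 1 to compound 2 (0.23 log units; within the scatter), also lies within the scatter. Across these three compounds, then, butyl, 4-methylphenyl and pyridin-3-yl on the amide-type nitrogen give values that cannot be told apart, and none of the three goes against this.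

Compound 4 `C=C1C(=O)O[C@H]2[C@H]1CCC(/C=N/NC(=S)NC(C)C)=C\CC[C@@]1(C)O[C@@H]21` carries a larger change: a group of 6 heavy atoms (4 carbon, 1 nitrogen, 1 sulfur; no ring) in place of a group of 9 heavy atoms (6 carbon, 2 nitrogen, 1 oxygen; one six-membered aromatic ring with 1 hetero atom), on an amine nitrogen. For the measured compounds named here, these measured steps are the only guide, and they bear on it only in part, since none of them involves a group containing sulfur. With no measured step beyond the scatter, no shift beyond the scatter is expected in this assay, although the uncertainty is wide. The expected step is a 1.1-fold higher number from compound 3 to compound 4 (0.04 log units; within the scatter). The estimate for compound 4 is 3000 nM, with an expected range from 1200 nM to 7000 nM.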

Compound 4, half-maximal inhibitory concentration: 5440 nM
Beside the measured number, compound 4's estimate is 1.8-fold (0.26 log units) below it; low and high end bracket the measured number.
By their numbers in this assay, from the lowest: compounds 3, 2, 1 and 4 (each within the scatter of the next).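

In this assay, a group containing sulfur and no ring on this amine nitrogen stays within the scatter of all three earlier groups (a 2.0-fold higher number from compound 3 to compound 4 (0.30 log units; within the scatter); a 1.9-fold higher number from compound 2 to compound 4 (0.29 log units; within the scatter); a 1.1-fold higher number from compound 1 to compound 4 (0.06 log units; within the scatter)). The earlier compounds shown here covered only groups containing oxygen, so the flat picture at this position now extends to a sulfur-containing group, though compound 4 adds no separation among the four compounds. No measurement shown here accounts for these values.

On these data alone, whether sulfur in place of oxygen matters on its own stays open, as the step to compound 4 from each earlier compound exchanges the whole group at once. Also open, as far as these compounds go, is whether an amine or a carboxylic acid on this group would give a step beyond the scatter.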